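This account rests on a few compounds, and the source may have more. Where it says the series, first, only, none or still open, it means among the compounds named here.

In a functional assay on the whole organism (strain Swiss) with Mus musculus as the target, in the maximal electroshock model, with a stated time of 2 h, at a dose of 300 mg/kg by the intraperitoneal route (on this read-out lower numbers stand for a weaker effect and higher numbers for a stronger effect at the one dose given), three compounds of one family have been tested so far. Compound 1 `CC(C(=O)N1CCN(c2ccc(Cl)cc2)CC1)N1C(=O)CCC1=O` gives 0%. Compound 2 `CCC(C(=O)N1CCN(c2ccc(C(F)(F)F)cc2)CC1)N1C(=O)CCC1=O` gives 0%. Compound 3 `CCC(C(=O)N1CCN(c2cccc(C)c2)CC1)N1C(=O)CCC1=O` gives 0%. On these numbers compound 3 stands level with compound 1 and compound 2; the gap from compound 3 to either of them lies within the scatter of repeated measurements, so none of the three can be called stronger or weaker than another, and all three sit at the bottom of what this read-out can report.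

Compound 4 `CCC(C(=O)N1CCN(c2ccc(Cl)cc2)CC1)N1C(=O)CCC1=O` has not yet been measured in this assay. It differs from compound 3 in one place: 4-chlorophenyl in place of 3-methylphenyl on an amine nitrogen in a ring. Going by the values given here, no pair of measured compounds differs in exactly this way, so no measured step shows what this exchange does. Compound 1 carries the same 4-chlorophenyl on its amine nitrogen in a ring and differs from compound 4 elsewhere; in this assay compound 1 gives 0%, the same as compound 3.

The step expected from compound 3 to compound 4 is therefore no change at the digits printed from compound 3 to compound 4 (within the scatter), none beyond the scatter, because in this assay compound 1 with the same 4-chlorophenyl gives 0%. Compound 4 is thus estimated to give 0% in this assay, with a likely range from 0% to 10%.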

Compound 4, a percentage reported as activity, at one dose (the size of the read-out at that dose, not a potency): 25%
Compound 4: the middle estimate sits 25 percentage points below what was measured; measured number outside the range, above it.
By their numbers in this assay, from the lowest: compounds 1, 2 and 3 (each within the scatter of the next); then compound 4.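

In this assay, the aromatic group on the amine nitrogen in a ring now makes a visible difference: 4-chlorophenyl in place of 3-methylphenyl gives a number 25 percentage points higher from compound 3 to compound 4 (beyond the scatter) and chloro in place of trifluoromethyl on an aromatic carbon gives a number 25 percentage points higher from compound 2 to compound 4 (beyond the scatter) with the rest of the molecule unchanged. The saturated chain carbon also matters, since methyl in place of hydrogen at that carbon, two bonds along the chain from an amide-type nitrogen in a ring and a carbonyl carbon, gives a number 25 percentage points higher from compound 1 to compound 4 (beyond the scatter) even with the 4-chlorophenyl kept in place. Among these four compounds, only compound 4 carries both the 4-chlorophenyl and this methyl, but nothing available here explains why the pairing goes with a higher read-out.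

As far as these compounds go, it remains open whether chloro is special on the aromatic ring or whether bromo or methoxy in its place would serve as well. Also open, from the compounds shown here alone, is whether a longer chain in place of that methyl would raise or lower the read-out, which at a single dose shows the size of the effect and not potency.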